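The compounds below may be only part of what the source reports. "The series", "measured", "known", "first", "only" and "open" are said of these compounds alone.

Measured compounds:
- compound 1 `CC(C)CCCCCCCCCCCCC(=O)N[C@@H]1[C@@H](O)[C@H](O)[C@@H](Nc2ncnc3[nH]cnc23)O[C@H]1C`: > 1000 uM
- compound 2 `CC(C)CCCCCCCCCCCCC(=O)NCC(=O)N[C@@H]1[C@@H](O)[C@H](O)[C@@H](Nc2ncnc3[nH]cnc23)O[C@H]1CO`: 0.69 uM

Among the measured compounds shown here, in a functional assay on L1210 cells (Mus musculus) for inhibition, with a stated time of 3 h (a higher number here means that more compound is needed for the effect, a lower number that less compound is needed), compound 2 gives 0.69 uM, the only numeric value here. For compound 1 this assay reports only a limit, > 1000 uM. That is the limit of > 1000 uM in this assay, at which 1 of the 2 values shown sits.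

Compound 3 `CCCCCCCCCCCCCCCC(=O)NCC(=O)N[C@@H]1[C@@H](O)[C@H](O)[C@@H](Nc2ncnc3[nH]cnc23)O[C@H]1CO` differs from compound 2 by propyl in place of isopropyl on a saturated chain carbon, ten or more bonds along the chain from a carbonyl carbon. For the measured compounds named here, no measured pair shows this change. The step is expected to stay within the usual scatter: a 1.0-fold higher number from compound 2 to compound 3 (0.01 log units; within the scatter) in this assay, with no clear direction. Compound 3 is therefore estimated at 0.7 uM, plausibly between 0.25 uM and 2 uM.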

Compound 3, concentration for half-maximal effect: 1.6 uM
Beside the measured number, compound 3's estimate is 2.3-fold (0.36 log units) below it; measured number inside the range.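

Swapping isopropyl for propyl on a saturated chain carbon is not silent: this assay shows a 2.3-fold higher number from compound 2 to compound 3 (0.37 log units; beyond the scatter) as a modest step. Among the compounds shown here, this is the first reading of what this change does at this position, and it shows that the shape of the chain end can move the number even with the atoms unchanged. Nothing measured here accounts for the step.

Going by these compounds, whether a longer chain, a shorter chain or an amine at the chain end would shift the number further remains open. So does whether a branch elsewhere along the chain would give a similar step.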